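Second ring-methyl position: expectation for compound 3

This account rests on a few compounds, and the source may have more. Where it says the series, first, only, none or still open, it means among the compounds named here.

Measured so far:
compound 1, `N/C(=N\NC(=S)N1CCCCCC1)c1ccccn1` — 36.6%
compound 2, `Cc1ccnc(/C(N)=N/NC(=S)N2CCCCCC2)c1` — 41.9%

In a functional assay on HeLa cells (Homo sapiens) for cytotoxicity, read by MTT assay, with a stated time of 72 h, tested at 3 uM (on this read-out lower numbers stand for less inhibition of growth and higher numbers for more inhibition of growth at the one concentration tested), compound 1 gives 36.6%, the lowest of the two numbers available. Compound 2 gives 41.9%, and the step of a number 5.3 percentage points higher from compound 1 to compound 2 (within the scatter) stays within the scatter of repeated measurements. Compound 3, `Cc1cccc(/C(N)=N/NC(=S)N2CCCCCC2)n1`, is not yet measured. It differs from compound 1 by methyl in place of hydrogen on an aromatic carbon, on an aromatic carbon of a six-membered aromatic ring with one nitrogen, next to the ring nitrogen, meta to a large group. Going by the values given here, the only measured step bearing on this is the one from compound 1 to compound 2, also a methyl entering on a ring carbon of the same core but at another place, a number 5.3 percentage points higher from compound 1 to compound 2 (within the scatter). On that basis no step beyond the scatter is expected from compound 1 to compound 3, a number 2.4 percentage points higher from compound 1 to compound 3 (within the scatter). Compound 3 is therefore estimated at 39%, in the range 27% to 52%.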

Compound 3, percent growth inhibition at one concentration: 63.6%
Beside the measured number, compound 3's estimate is 24.6 percentage points below it; measured number above the stated range.
By their numbers in this assay, from the lowest: compounds 1 and 2 (each within the scatter of the next); then compound 3.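

In this assay, methyl in place of hydrogen on an aromatic carbon does not act alike at every place on the shared core: next to the ring nitrogen, meta to a large group, it gives a number 27 percentage points higher from compound 1 to compound 3 (beyond the scatter) and so stands beyond the scatter, whereas at the other place, in compound 2, it gives a number 5.3 percentage points higher from compound 1 to compound 2 (within the scatter) and stays within it. The place of this single added methyl therefore matters in this pair of steps, which compound 2 alone could not show. Nothing measured here accounts for the gain at this position.

As far as these compounds go, whether an ethyl chain, a methoxy group or an amine at the same place would keep this gain remains open. Also open, from the compounds shown here alone, is whether the step from this one tested concentration holds across a full concentration range.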